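From 3-Methylphenyl to 3-Chloro-4-methylphenyl on the Shared Core

The compounds below may be only part of what the source reports. "The series", "measured", "known", "first", "only" and "open" are said of these compounds alone.

Of the compounds shown here, three on a shared core have been measured in an assay on COS-7 cells for agonist activity at Free fatty acid receptor 1 (Homo sapiens), read by scintillation counting and inositol phosphate accumulation, with a stated time of 90 min; on this read-out higher numbers stand for an effect only at larger amounts of compound and lower numbers for an effect already at smaller amounts. Compound 1 `Cc1cc(=O)oc2cc(OCc3nc(N)nc(Nc4ccc(Cl)cc4)n3)ccc12` gives 32500 nM, compound 2 `Cc1cccc(Nc2nc(N)nc(COc3ccc4c(C)cc(=O)oc4c3)n2)c1` gives 1780 nM, and compound 3 `Cc1cc(=O)oc2cc(OCc3nc(N)nc(Nc4ccc(C5CC5)cc4)n3)ccc12` gives 700 nM. Compound 2 thus stands second highest of the three, with compound 3 nearest and compound 1 furthest away. Compound 4 `Cc1ccc(Nc2nc(N)nc(COc3ccc4c(C)cc(=O)oc4c3)n2)cc1Cl` carries 3-chloro-4-methylphenyl in place of 3-methylphenyl on a nitrogen on an aromatic ring. For the measured compounds named here, two measured steps bear on this change: an 18-fold lower number from compound 1 to compound 2 (1.26 log units; beyond the scatter) and a 2.5-fold lower number from compound 2 to compound 3 (0.41 log units; beyond the scatter) show that the group on this nitrogen matters strongly, and that a chloro alone on the ring did poorly while a larger carbon group did well. Compound 4 keeps a methyl and adds a chloro, so in this assay a modest step downward from compound 2 is expected, of about a 1.5-fold lower number from compound 2 to compound 4 (0.17 log units; within the scatter). The estimate for compound 4 in this assay is therefore 1200 nM, with a range from 300 nM to 5000 nM.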

Compound 4, half-maximal effective concentration: 140 nM
Beside the measured number, compound 4's estimate is 8.6-fold (0.93 log units) above it, and the stated range ends above it.
By their numbers in this assay, from the lowest: compound 4; then compound 3; then compound 2; then compound 1.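

In this assay, 3-chloro-4-methylphenyl in place of 3-methylphenyl gives a 13-fold lower number from compound 2 to compound 4 (1.10 log units; beyond the scatter), so a chloro on this ring can go with a low number, which compound 1 alone had not suggested; the same position also shows a 230-fold lower number from compound 1 to compound 4 (2.37 log units; beyond the scatter). A cyclopropyl group is not the best seen here either, as a 5.0-fold lower number from compound 3 to compound 4 (0.70 log units; beyond the scatter) shows, and compound 4 now has the lowest number of the four, with all its steps beyond the scatter. No accompanying measurement explains these differences.

The compounds shown leave open how much of the drop belongs to the chloro and how much to the methyl in 3-chloro-4-methylphenyl. They also leave open how a methoxy, a trifluoromethyl or an amine on this ring would compare.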